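Shortening the urea chain from ethyl to methyl

The compounds below may be only part of what the source reports. "The series", "measured", "known", "first", "only" and "open" are said of these compounds alone.

Compound 3 `CCNC(=O)N1CC1C#N` stands second highest of the three numbers in a functional assay on MCF7 cells (Homo sapiens) for inhibition (a higher number here means a weaker inhibitor, a lower number a stronger inhibitor), where compound 3 gives 20000 nM. Compound 1 `CCCCNC(=O)N1CC1C#N` gives 6700 nM in this assay, and compound 2 `CC(C)(C)NC(=O)N1CC1C#N` gives 190000 nM. The step of a 3.0-fold higher number from compound 1 to compound 3 (0.47 log units; beyond the scatter) and the step of a 9.5-fold lower number from compound 2 to compound 3 (0.98 log units; beyond the scatter) place compound 3 between the other two, while the step of a 28-fold higher number from compound 1 to compound 2 (1.45 log units; beyond the scatter) is the largest of the three. Compound 4 `CNC(=O)N1CC1C#N` differs from compound 3 by hydrogen in place of methyl on a saturated chain carbon bound to an amide-type nitrogen. Among the measured compounds shown here, the measured step that bears on this change is the one from compound 1 to compound 3, a shortening of the same kind of chain, which raised the number modestly; the two steps involving compound 2 concern a branched group and bear less directly. A further shortening is therefore expected to raise the number again by a modest amount, and the expected step is a 2.3-fold higher number from compound 3 to compound 4 (0.35 log units; beyond the scatter). Compound 4 is thus expected to give about 45000 nM in this assay, within an estimated range from 15000 nM to 150000 nM.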

Compound 4, half-maximal inhibitory concentration: 17000 nM
Estimate against measurement, compound 4: 2.6-fold (0.42 log units) above, within the range that was stated.
By their numbers in this assay, from the lowest: compound 1; then compounds 4 and 3 (each within the scatter of the next); then compound 2.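

In this assay, the change from ethyl to methyl on the urea nitrogen leaves the number unchanged within the scatter (a 1.2-fold lower number from compound 3 to compound 4 (0.07 log units; within the scatter)), so the rise seen on going from butyl to ethyl does not continue at this end of the chain. Butyl remains apart from the shortest chain (a 2.5-fold higher number from compound 1 to compound 4 (0.40 log units; beyond the scatter)), and tert-butyl stands apart from it on the other side (an 11-fold lower number from compound 2 to compound 4 (1.05 log units; beyond the scatter)), so among these compounds the differences lie with butyl and tert-butyl, not with ethyl against methyl. Nothing available explains this flat step.

The compounds shown leave open whether a longer chain such as hexyl would lower the number further than butyl does. They also leave open where propyl or isopropyl would fall.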